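Changing the Aryl Group on the Ring Nitrogen

The source may report more compounds than this note shows. Statements on the series, on what has been measured and on what is new or still open speak of the compounds shown alone.

Of the compounds shown here, three have been measured in an in vitro functional assay on HEK293-A cells for negative allosteric modulation of metabotropic glutamate receptor 5 (Homo sapiens), read by FLIPR and calcium flux (on this read-out lower numbers stand for stronger inhibition and higher numbers for weaker inhibition), and all share a common core. Compound 1 `C[C@H](c1ccccc1)N1C[C@H](c2nc(-c3cccc(Cl)c3)no2)CC1=O` gives 1600 nM. Compound 2 `O=C1CC(c2nc(-c3cccc(Cl)c3)no2)CN1c1ccccc1Cl` gives 680 nM, and compound 3 `O=C1COc2ccccc2N1Cc1nc(-c2cccc(Cl)c2)no1` gives 770 nM. Compound 2 has the lowest of the three numbers, but its gap to compound 3 lies within the usual scatter of repeated measurements, so those two cannot be told apart. Only compound 1 stands clearly apart from compound 2, with a higher number that is beyond the scatter.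

Compound 4 `Cc1cccc(N2CC(c3nc(-c4cccc(Cl)c4)no3)CC2=O)c1` has not yet been measured. It differs from compound 2 in a single place: 3-methylphenyl in place of 2-chlorophenyl on an amide-type nitrogen in a ring. Everything else in the structure is kept.

Among the compounds with values here, no measured pair here shows a change of this kind, so there is no direct guide to its effect. Both the leaving and the entering group are a single six-membered aromatic ring of carbon only, with no hydrogen-bond donors or acceptors, so the expectation is a step from compound 2 to compound 4 that stays close to the scatter, with no clear direction: a 1.3-fold higher number from compound 2 to compound 4 (0.12 log units; within the scatter) is what is expected. Compound 4 is therefore estimated at 900 nM in this assay, with a range from 350 nM to 2500 nM.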

Compound 4, half-maximal inhibitory concentration: 2300 nM
Compound 4: middle estimate off by 2.6-fold (0.41 log units), on the low side; measured number inside the range.
By their numbers in this assay, from the lowest: compounds 2 and 3 (each within the scatter of the next); then compounds 1 and 4 (each within the scatter of the next).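

In this assay, the aryl group on the amide-type nitrogen matters: 3-methylphenyl in place of 2-chlorophenyl gives a 3.4-fold higher number from compound 2 to compound 4 (0.53 log units; beyond the scatter) and so weakens inhibition. Within the data shown here, the earlier compounds offered no pair differing in one place, so this is the first direct view of this position, and it shows that two groups can differ in this read-out even when each is a single six-membered aromatic ring of carbon only, with the same count of heavy atoms and no hydrogen-bond donors or acceptors. No measurement at hand accounts for the step.

The compounds shown leave open whether the step follows the exchange of chloro for methyl or the different numbering in the two group names, a question that 2-methylphenyl or 3-chlorophenyl on the same nitrogen could separate. They also leave open how a plain phenyl, or an aromatic ring carrying an amine or a carboxylic acid, would behave at this position.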